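Triazole aryl exchange carried from one core to another

This account rests on a few compounds, and the source may have more. Where it says the series, first, only, none or still open, it means among the compounds named here.

Measured in a functional assay on A549 cells (Homo sapiens) for cytotoxicity, read by MTT assay, with a stated time of 4 days; on this read-out higher numbers stand for weaker inhibition and lower numbers for stronger inhibition:
- compound 1 `C=C1C(=O)[C@]23C[C@@]1(O)CC[C@H]2c1ccc(OS(=O)(=O)c2ccc(C)cc2)c(C)c1[C@@H]3Cn1cc(-c2ccccn2)nn1`: 2310 nM
- compound 2 `C=C1C(=O)[C@]23C[C@@]1(O)CC[C@H]2c1ccc(OS(=O)(=O)c2ccc(C)cc2)c(C)c1[C@@H]3Cn1cc(-c2ccc(Cl)cc2)nn1`: 1870 nM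
- compound 3 `Cc1ccc(S(=O)(=O)Oc2ccc3c(c2C)[C@H](Cn2cc(-c4ccc(Cl)cc4)nn2)[C@@]24CC(=O)[C@@](C)(CC[C@@H]32)C4)cc1`: > 20000 nM, which is a limit of the assay and not a number.

Compound 1 and compound 2 share one core and differ in one place: pyridin-2-yl in place of 4-chlorophenyl on an aromatic carbon. That exchange gave a 1.2-fold higher number from compound 2 to compound 1 (0.09 log units; within the scatter). Compound 3 carries the same 4-(4-chlorophenyl)-1H-1,2,3-triazol-1-yl group on another core; how its core differs from that of compound 2 is not broken down here. For compound 3 the result is the limit of > 20000 nM in this assay, at which 1 of the 3 values shown sits.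

Compound 4 `Cc1ccc(S(=O)(=O)Oc2ccc3c(c2C)[C@H](Cn2cc(-c4ccccn4)nn2)[C@@]24CC(=O)[C@@](C)(CC[C@@H]32)C4)cc1` has not yet been measured in this assay. It stands to compound 3 as compound 1 stands to compound 2: pyridin-2-yl in place of 4-chlorophenyl on an aromatic carbon. The two place descriptions read the same word for word, so this is the same change, now made on the core of compound 3. Because a 1.2-fold higher number from compound 2 to compound 1 (0.09 log units; within the scatter) lies within the scatter, the change is not expected to move compound 4 far from where compound 3 sits, and with compound 3 at the limit of > 20000 nM in this assay, at which 1 of the 3 values shown sits, a second limit is the likeliest outcome. The expected step is a step that the limit leaves unreadable from compound 3 to compound 4. In this assay compound 4 is expected to give about 25000 nM, with the estimate spanning 10000 nM to 80000 nM.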

Compound 4, half-maximal inhibitory concentration: > 20000 nM
Compound 4 gave a limit, no number (the forecaster's own chance of this, stated with the estimate: 75%); the middle value does not contradict the limit.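

In this assay compound 4 gives > 20000 nM, a limit of the assay and not a number. Compound 3 also sits at a limit, so no step from compound 3 to compound 4 can be read: the limit of > 20000 nM in this assay, at which 2 of the 4 values shown sit.

The compounds shown leave open whether pyridin-2-yl in place of 4-chlorophenyl changes anything on the core of compound 3.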